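A few compounds are considered here, and "the series" means these few. Any claim that something is new, unique, unknown or untested is made for them only; others in the source may bear on it.

Three compounds sharing a five-membered aromatic ring with three nitrogen atoms have been measured in a functional assay on the whole organism (strain albino) for inhibition, with Rattus norvegicus as the target, read by paw edema, with a stated time of 3 h, at a dose of 0.28 mmol/kg by the oral route; on this read-out lower numbers stand for less inhibition and higher numbers for more inhibition at the one dose given (going by the name of the read-out). Compound 1 `COc1ccc(-c2nnc(SC/C(=N/O)c3ccccc3)n2-c2ccccc2)cc1` gives 63% in this assay. Compound 2 `COc1ccc(-c2nnc(SCC(=O)c3ccccc3)n2-c2ccccc2)cc1OC` gives 59%, and compound 3 `C=CCn1c(SCC(=O)c2ccccc2)nnc1-c1ccc(OC)c(OC)c1` gives 64%. The three numbers lie within the usual scatter of one another, so none of the three compounds can be set apart from the others on this read-out.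

Compound 2 and compound 3 differ in one place: allyl in place of phenyl on an aromatic nitrogen. This change gives a number 5 percentage points higher from compound 2 to compound 3 (within the scatter), which lies within the scatter. The difference between the core of compound 1 and the core of compound 2 is not broken down here.

Compound 4 `C=CCn1c(SC/C(=N/O)c2ccccc2)nnc1-c1ccc(OC)cc1` has not yet been measured in this assay. It differs from compound 1 by the same kind of change as that from compound 2 to compound 3: allyl in place of phenyl on an aromatic nitrogen. The surroundings are not identical, however. In compound 1 the aromatic nitrogen is next to the ring atom that bears a 4-methoxyphenyl group and next to the ring atom that bears a large group, whereas in compound 2 it is next to the ring atom that bears a (benzoylmethyl)sulfanyl group and next to the ring atom that bears a 3,4-dimethoxyphenyl group.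

Going by the values given here, the one measured example of this kind of change stayed within the scatter, so a similarly small expected step is assumed, a number 3 percentage points higher from compound 1 to compound 4 (within the scatter). Compound 4 is therefore estimated to give 66% in this assay. The expected range for compound 4 runs from 55% to 77%.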

Compound 4, a percentage reported as inhibition, in the whole organism at one dose (the size of the read-out at that dose, not a potency): 67%
Beside the measured number, compound 4's estimate is 1 percentage points below it, and the stated range covers the measured number.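

In this assay, putting allyl in place of phenyl on the aromatic nitrogen gives a number 4 percentage points higher from compound 1 to compound 4 (within the scatter). Set beside the only other example of this change, on a different core, the two steps agree: the same change on two cores in this assay, a number 5 percentage points higher (within the scatter) from compound 2 to compound 3 and a number 4 percentage points higher (within the scatter) from compound 1 to compound 4, 1 percentage points apart, within the scatter of two such steps This shows that the exchange of phenyl for allyl could be carried from the core of compound 2 to the core of compound 1 without any step that stands out from the scatter, but it does not show that allyl gives more inhibition than phenyl, and two cores, read at a single dose and a single time, offer no basis for a rule across the wider series.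

As far as these compounds go, what stays open is whether a saturated propyl chain, a longer chain, or a chain ending in an amine or a carboxylic acid on that aromatic nitrogen would remain in the same range of inhibition. Also open, from the compounds shown here alone, are the separate contributions of the oxime and the carbonyl, since the compounds carrying them also differ in their methoxy groups, so neither change can be read alone here.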